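The source may hold more compounds than are shown below. What is called first, only, known or untested is meant among the compounds shown, and "the series" means these compounds.

Three compounds that share one core have been taken into a functional assay on HCT-116 cells (Homo sapiens) for cytotoxicity, read by MTT assay, with a stated time of 72 h; on this read-out lower numbers stand for stronger inhibition and higher numbers for weaker inhibition. Compound 1 `Nc1cccc(Nc2c(C(=O)NCc3ccc(F)cc3)nc(Br)c3cccnc23)c1` gives > 10000 nM, which is a limit of the assay and not a number. Compound 2 `N[C@H]1CC[C@H](Nc2c(C(=O)NCc3ccco3)nc(Br)c3cccnc23)CC1` gives > 10000 nM, which is also a limit. For compound 3 `N[C@H]1CC[C@H](Nc2c(C(=O)NCc3ccc(Oc4ccccc4)cc3)nc(Br)c3cccnc23)CC1` the entry reads "not determined" (no result reported), so it adds no information on strength. Compound 1 therefore stands with the majority of this small set: the limit of > 10000 nM in this assay, at which 2 of the 3 values shown sit.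

Compound 4 `Nc1ccc(Nc2c(C(=O)NCc3ccc(F)cc3)nc(Br)c3cccnc23)cc1` has not yet been measured. It differs from compound 1 in a single place, with 4-aminophenyl in place of 3-aminophenyl on a nitrogen on an aromatic ring. Among the measured compounds shown here, no measured pair here shows what such a swap does, so no step beyond the usual scatter is expected in this assay, in either direction. In numbers, the expected change is a step that the limit leaves unreadable from compound 1 to compound 4. This expectation leans on compound 1 and its limit of > 10000 nM. For compound 4, the estimated value is 12000 nM, with an expected range from 3000 nM to 40000 nM.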

Compound 4, half-maximal inhibitory concentration: 10000 nM
Beside the measured number, compound 4's estimate is 1.2-fold (0.08 log units) above it, and the stated range covers the measured number.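

Putting 4-aminophenyl in place of 3-aminophenyl on a nitrogen on an aromatic ring gives, in this assay, a number no higher from compound 1 to compound 4 (the limit leaves the size open). For compound 1, the entry > 10000 nM is a limit and not a number. Compound 4 is the first compound here to give a number rather than a limit, yet that number matches the figure of the limit, so this change of the amino group's place shows no strong cytotoxicity: the limit of > 10000 nM in this assay, at which 2 of the 4 values shown sit.

The compounds shown leave open how much weaker compound 1 really is, since its limit hides its true value. They also leave open whether a different group on this nitrogen, such as 2-aminophenyl or a phenyl ring carrying a carboxylic acid, would bring the value clearly lower in this assay.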